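Swapping a dihydroxyphenyl for a quinone on a pyrazole core

The source may hold more compounds than are shown below. What is called first, only, known or untested is meant among the compounds shown, and "the series" means these compounds.

Compound 1 `Oc1ccc(O)c(-c2cc(-c3ccc(Cl)cc3)nn2-c2ccccc2)c1` and compound 3 `O=C1C=CC(=O)C(c2cc(-c3ccc(Cl)cc3)nn2-c2ccccc2)=C1` share a core and differ in one place: a group of 8 heavy atoms (6 carbon, 2 oxygen; one six-membered non-aromatic ring of carbon only) in place of a group of 8 heavy atoms (6 carbon, 2 oxygen; one six-membered aromatic ring of carbon only), on an aromatic carbon. In a functional assay on cells (Cancer cell lines, Homo sapiens) for cytotoxicity, read by sulforhodamine B assay, with a stated time of 48 h (a higher number here means a weaker inhibitor of growth, a lower number a stronger inhibitor of growth), compound 1 gives 8010 nM and compound 3 gives 67300 nM, so the step is an 8.4-fold higher number from compound 1 to compound 3 (0.92 log units; beyond the scatter).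

Compound 2 `CC(=O)NS(=O)(=O)c1ccc(-n2nc(-c3ccccc3)cc2-c2cc(O)ccc2O)cc1` differs from compound 1 in more than one place, and that difference between the two cores is not broken down here. In this assay compound 2 gives 100000 nM, the highest of the three numbers measured.

Compound 4 `CC(=O)NS(=O)(=O)c1ccc(-n2nc(-c3ccccc3)cc2C2=CC(=O)C=CC2=O)cc1` is made from compound 2 by the same kind of change: a group of 8 heavy atoms (6 carbon, 2 oxygen; one six-membered non-aromatic ring of carbon only) in place of a group of 8 heavy atoms (6 carbon, 2 oxygen; one six-membered aromatic ring of carbon only), on an aromatic carbon. The surroundings differ from the earlier pair: here the place is next to the ring atom that bears a large group and two ring bonds from the ring atom that bears a phenyl group, whereas in compound 1 it was next to the ring atom that bears a phenyl group and two ring bonds from the ring atom that bears a 4-chlorophenyl group.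

Because compound 2 already gives 100000 nM, the highest of the three measured numbers, only a small further change is expected for compound 4. The expected step is a 1.5-fold higher number from compound 2 to compound 4 (0.18 log units; within the scatter). This expected step is smaller than the measured step of an 8.4-fold higher number from compound 1 to compound 3 (0.92 log units; beyond the scatter). Compound 4 is estimated at 150000 nM, expected between 60000 nM and 500000 nM.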

Compound 4, concentration for 50% growth inhibition: 100000 nM
The estimate for compound 4 lay 1.5-fold (0.18 log units) above the measured number, and the stated range covers the measured number.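

On the second core, putting the non-aromatic ring in place of the 2,5-dihydroxyphenyl gives no change at the digits printed from compound 2 to compound 4 (within the scatter) in this assay. Among the compounds shown here, the size of the step seen on one core therefore did not carry over to the other: the same change on two cores in this assay, an 8.4-fold higher number (0.92 log units; beyond the scatter) from compound 1 to compound 3 and no change at the digits printed (within the scatter) from compound 2 to compound 4, 8.4-fold (0.92 log units) apart, beyond the scatter of two such steps This rests on only two pairs of compounds, and the two cores differ in more than one place, so it does not show which part of the core goes with the difference, nor why the steps differ.

Still open, going by these compounds, is whether the 4-chlorophenyl group of compound 1 or the large group of compound 2 goes with the size of the step. Also open, on these data alone, is what an amine or a carboxylic acid in place of the 2,5-dihydroxyphenyl would give on either core in this assay.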